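Dimethylamino in Place of Amino on the Shared Core

This account rests on a few compounds, and the source may have more. Where it says the series, first, only, none or still open, it means among the compounds named here.

Compound 3 `Nc1ccc(-c2cc(=O)c3c(N)c(F)c(N)c(F)c3o2)cc1F` gives 7.7 nM in a functional assay on MCF7 cells (Homo sapiens) for cytotoxicity, read by neutral red uptake, with a stated time of 3 days; a higher number here means a weaker inhibitor, a lower number a stronger inhibitor. Among the numbers shown it is the lowest. Compound 2 `Nc1ccc(-c2cc(=O)c3c(N)c(F)c(Cl)c(F)c3o2)cc1F` gives 210 nM in this assay, and the step of a 27-fold lower number from compound 2 to compound 3 (1.44 log units; beyond the scatter) is large. Compound 1 `Nc1ccc(-c2cc(=O)c3c(N)c(F)c(O)c(F)c3o2)cc1F` reaches only the limit of this assay, at > 10000 nM (the limit of > 10000 nM in this assay, at which 1 of the 3 values shown sits). The step of an at least 1200-fold lower number from compound 1 to compound 3 (3.11 log units; beyond the scatter) is thus itself a limit, though a large one, as is an at least 47-fold lower number from compound 1 to compound 2 (1.67 log units; beyond the scatter).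

Compound 4 `CN(C)c1c(F)c(N)c2c(=O)cc(-c3ccc(N)c(F)c3)oc2c1F` differs from compound 3 in one place: dimethylamino in place of amino on an aromatic carbon. For the measured compounds named here, no measured step alters the amino group once it is in place; the two steps that end at compound 3 both put an amino group on that carbon, and both moved the number down strongly. Compound 4 keeps a nitrogen there but as a dimethylamino group with no hydrogen-bond donor. Going by these compounds, whether that keeps the gain is untested here, so the expectation is a step beyond the scatter towards a higher number, yet smaller than the steps into compound 3. Compound 4 is therefore expected to give 60 nM in this assay, between 10 nM and 400 nM, the estimated step being a 7.8-fold higher number from compound 3 to compound 4 (0.89 log units; beyond the scatter).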

Compound 4, half-maximal inhibitory concentration: 39 nM
The estimate for compound 4 lay 1.5-fold (0.19 log units) above the measured number; the range from low to high includes it.
By their numbers in this assay, from the lowest: compound 3; then compound 4; then compound 2. At a limit, above all of these: compound 1.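

For the compounds shown here, the earlier steps showed only that putting an amino group on this aromatic carbon, ortho to two fluoro groups, gives a lower number than chloro or hydroxy; the new result, a 5.1-fold higher number from compound 3 to compound 4 (0.70 log units; beyond the scatter), is the first to alter the amino group itself, and the change gives back only part of that gain. Dimethylamino counts no hydrogen-bond donor where amino counts one, yet it still improves on chloro, with a 5.4-fold lower number from compound 2 to compound 4 (0.73 log units; beyond the scatter), so on this core a donor on that nitrogen is not needed for a number lower than that of compound 2. Compound 1 stands only at a limit of this assay, so the step of an at least 250-fold lower number from compound 1 to compound 4 (2.40 log units; beyond the scatter) is itself a limit: the limit of > 10000 nM in this assay, at which 1 of the 4 values shown sits.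

A methylamino group, with one methyl on the nitrogen instead of two, would show whether the rise from amino to dimethylamino comes in stages or appears only when both hydrogens are replaced. Where a ring amine such as pyrrolidine or morpholine, or an acetamide, would fall among these numbers also remains open.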